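Urea aryl variation on a shared core: isoxazole replacement

The source may report more compounds than this note shows. Statements on the series, on what has been measured and on what is new or still open speak of the compounds shown alone.

Among the measured compounds shown here, compound 3 `Cc1cc(C)cc(NC(=O)Nc2ccc(Nc3ncnc4c3OCCN4)cc2)c1` gives 971 nM in an assay on isolated protein for inhibition of proto-oncogene tyrosine-protein kinase receptor Ret variant V804M (Homo sapiens), read by 33P incorporation, with stated times of 15 min and 40 min (a lower number here means a stronger inhibitor, a higher number a weaker inhibitor), the highest of the three numbers measured so far. Its nearest neighbour is compound 2 `COc1ccc(NC(=O)Nc2ccc(Nc3ncnc4c3OCCN4)cc2)cc1`, which gives 824 nM; the step of a 1.2-fold higher number from compound 2 to compound 3 (0.07 log units; within the scatter) lies within the scatter, so no order between these two is claimed. Compound 1 `O=C(Nc1ccc(Nc2ncnc3c2OCCN3)cc1)Nc1ccc(C(F)(F)F)cc1` gives 276 nM, and a 3.5-fold higher number from compound 1 to compound 3 (0.55 log units; beyond the scatter) is a modest step beyond the scatter; a 3.0-fold higher number from compound 1 to compound 2 (0.48 log units; beyond the scatter) is of the same kind.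

Compound 4 `CC(C)(C)c1cc(NC(=O)Nc2ccc(Nc3ncnc4c3OCCN4)cc2)no1` is not yet measured. It differs from compound 3 by 5-(tert-butyl)-1,2-oxazol-3-yl in place of 3,5-dimethylphenyl on an amide-type nitrogen. All three measured steps sit on the same amide-type nitrogen, but each swaps substituents on a six-membered ring of carbon only; none exchanges that ring for a five-membered ring with hetero atoms, so the measured steps bear on the place of the change rather than on its nature. Across those steps the numbers moved by no more than the size of a 3.5-fold higher number from compound 1 to compound 3 (0.55 log units; beyond the scatter), and the two larger aryl groups gave numbers within the scatter of each other. The expectation for compound 4 in this assay is therefore a step of about a 1.6-fold lower number from compound 3 to compound 4 (0.21 log units; within the scatter), with no direction that can be called beyond the scatter, and a wide range. Compound 4 is estimated at 600 nM, between 150 nM and 2500 nM.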

Compound 4, half-maximal inhibitory concentration: 34 nM
The estimate for compound 4 lay 18-fold (1.25 log units) above the measured number; measured number below the stated range.
By their numbers in this assay, from the lowest: compound 4; then compound 1; then compounds 2 and 3 (each within the scatter of the next).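

Notes on the urea aryl position: in this assay, swaps among substituted six-membered carbon rings on the amide-type nitrogen had given only modest steps or none beyond the scatter, yet the exchange for 5-(tert-butyl)-1,2-oxazol-3-yl gives a 29-fold lower number from compound 3 to compound 4 (1.46 log units; beyond the scatter) and a 24-fold lower number from compound 2 to compound 4 (1.38 log units; beyond the scatter) as large steps. Against the lowest number among the earlier compounds, the exchange still gives an 8.1-fold lower number from compound 1 to compound 4 (0.91 log units; beyond the scatter) as a modest step beyond the scatter, which places compound 4 lowest of the four in this series. This position therefore tolerates more change in the number than the earlier substituent swaps showed, while the available data contain nothing that bears on the reason for the shift.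

The exchange alters the ring and its substituent in one step, so the shares of the 1,2-oxazole ring and the tert-butyl group remain unseparated; a phenyl ring carrying tert-butyl and a 1,2-oxazole ring carrying methyl would divide them. Also open, from the compounds shown here alone, is how an amine or a longer alkyl chain in place of tert-butyl on the five-membered ring would read in this assay in comparison with compound 4.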